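Chloro to Bromo on the Shared Core, Antiproliferative Effect

The source may hold more compounds than are shown below. What is called first, only, known or untested is meant among the compounds shown, and "the series" means these compounds.

Among the measured compounds shown here, compound 2 `COc1ccc(-c2c(Cl)c(=O)c3c(OC)cc(OC)cc3n2S(=O)(=O)c2ccc(OC)cc2)cc1` is the only member of this set with a number in an ADME assay on BJ cells (Homo sapiens) for antiproliferative activity, with a stated time of 72 h (a lower number here means that less compound is needed, a higher number that more compound is needed for the effect), where compound 2 gives 90000 nM. Compound 1 `COc1ccc(-c2cc(=O)c3c(OC)cc(OC)cc3[nH]2)cc1` reaches only a limit of this assay, giving > 62000 nM. For the measured compounds named here, that limit of > 62000 nM in this assay, at which 1 of the 2 values shown sits, leaves no measured step between the two. Compound 3 `COc1ccc(-c2c(Br)c(=O)c3c(OC)cc(OC)cc3n2S(=O)(=O)c2ccc(OC)cc2)cc1` carries bromo in place of chloro on an aromatic carbon. Going by the values given here, with no measured step to lean on, no change beyond the usual scatter is expected in this assay in either direction. The step is estimated as a 1.1-fold lower number from compound 2 to compound 3 (0.02 log units; within the scatter). Compound 3 is therefore estimated at 85000 nM, with a range from 30000 nM to 250000 nM.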

Compound 3, half-maximal effective concentration: 49700 nM
Compound 3: middle estimate off by 1.7-fold (0.23 log units), on the high side; low and high end bracket the measured number.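

In this assay, among the compounds shown here, the only measured step at this position is a 1.8-fold lower number from compound 2 to compound 3 (0.26 log units; within the scatter). Bromo in place of chloro on this aromatic carbon, ortho to a 4-methoxyphenyl group, therefore leaves the read-out within the scatter. Both halogen compounds give numbers, so this change can be read, but one value in the set still cannot be compared: the limit of > 62000 nM in this assay, at which 1 of the 3 values shown sits.

On these data alone, whether an amine or a nitrile on this carbon would move the number beyond the scatter stays open. As far as these compounds go, what the (4-methoxyphenyl)sulfonyl group contributes on its own also stays open.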